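Dropping the bromo group from compound 1

This account rests on a few compounds, and the source may have more. Where it says the series, first, only, none or still open, it means among the compounds named here.

In a functional assay on 786-0 cells (Homo sapiens) for inhibition, read by spectrophotometry and sulforhodamine B assay, with a stated time of 48 h (a higher number here means a weaker inhibitor of growth, a lower number a stronger inhibitor of growth), compound 1 `S=C(N/N=C/c1c[nH]c2ccc(Br)cc12)Nc1cccc2ccccc12` gives 6560 nM. Within the data shown here, the only other measured compound, compound 2 `Cc1ccc(NC(=S)N/N=C/c2c[nH]c3ccccc23)cc1`, gives 3990 nM. These two values lie within the scatter of each other, so compound 1 does not stand apart from compound 2. Compound 3 `S=C(N/N=C/c1c[nH]c2ccccc12)Nc1cccc2ccccc12` has yet to be measured. It keeps the core of compound 1 and differs from it in one place: hydrogen in place of bromo on an aromatic carbon. Hydrogen replaces bromo on an aromatic carbon of a six-membered aromatic ring of carbon only, part of a fused or bridged system of two rings. Among the measured compounds shown here, no measured pair isolates this change, so the expectation rests on limited evidence. Compound 2 also carries no bromo group and gives 3990 nM, which is within the scatter of compound 1. On that basis, no step beyond the scatter is expected in this assay, and no direction can be firmly expected. The estimated step is a 1.3-fold lower number from compound 1 to compound 3 (0.12 log units; within the scatter). For compound 3, the expected value is 5000 nM, with an estimated range of 2000 nM to 12000 nM.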

Compound 3, concentration for 50% growth inhibition: 250 nM
Estimate against measurement, compound 3: 20-fold (1.30 log units) above; the measured number lies below the stated range.
By their numbers in this assay, from the lowest: compound 3; then compounds 2 and 1 (each within the scatter of the next).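

In this assay this position proves far from indifferent: hydrogen in place of bromo on an aromatic carbon, meta to a fused ring and para to a fused ring, gives a 26-fold lower number from compound 1 to compound 3 (1.42 log units; beyond the scatter), a large step. Compound 1 and compound 2 could not show this: they differ in more than one place, and their values lie within the scatter of each other. Among these compounds, this pair isolates the change for the first time, and in it the compound carrying bromo is the weaker inhibitor of growth, although nothing at hand accounts for the size of the step.

The compounds shown leave open whether this step is particular to bromo or would also be seen with other groups on this aromatic carbon, such as chloro, fluoro, methoxy or an amine. They also leave open whether bromo at this place would bring a step of similar size in a compound that otherwise matches compound 2, as this single pair is all that carries the change.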